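Replacing the acrylamide of compound 2 with a diamine chain

This account rests on a few compounds, and the source may have more. Where it says the series, first, only, none or still open, it means among the compounds named here.

Three ureas sharing one core have been measured in a functional assay on BaF3 cells (Mus musculus) for inhibition, read by CCK-8 assay, with a stated time of 72 h; on this read-out lower numbers stand for stronger inhibition of growth and higher numbers for weaker inhibition of growth. Among the compounds with values here, compound 1 `CCN1CCN(Cc2ccc(NC(=O)Nc3ccc(Oc4cc(NC(C)=O)ncn4)cc3)cc2C(F)(F)F)CC1` gives 38 nM in this assay, and compound 3 `CC(=O)Nc1cc(Oc2ccc(NC(=O)Nc3ccc(CN4CCN(C)CC4)c(C(F)(F)F)c3)cc2)ncn1` gives 50 nM; the only single-site step recorded among them, a 1.3-fold higher number from compound 1 to compound 3 (0.12 log units; within the scatter), is small. Compound 2 `C=CC(=O)Nc1cc(Oc2ccc(NC(=O)Nc3ccc(C)c(C(F)(F)F)c3)cc2)ncn1` gives 1940 nM and stands highest of the three numbers, a gap beyond the scatter to both compound 3 and compound 1, though it differs from each of them in more than one place, so no single change can be credited with that gap.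

Compound 4 `CNCCN(C)c1cc(Oc2ccc(NC(=O)Nc3ccc(C)c(C(F)(F)F)c3)cc2)ncn1` arises from compound 2 by one change: methyl(2-(methylamino)ethyl)amino in place of (vinylcarbonyl)amino on an aromatic carbon. Within the data shown here, no measured step touches this position or this kind of exchange, and the one recorded step, from compound 1 to compound 3, concerns a different part of the molecule and lies within the scatter. Among the measured compounds shown here, the account therefore has no precedent on which to base a direction.

With nothing to point either way, compound 4 is expected to land near compound 2, with the step of a 1.3-fold lower number from compound 2 to compound 4 (0.11 log units; within the scatter) estimated as not beyond the scatter. The estimate for compound 4 in this assay is 1500 nM, within a wide range from 300 nM to 8000 nM.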

Compound 4, concentration for 50% growth inhibition: > 10000 nM
Compound 4: only a limit was reported; the forecaster's own chance of this, stated with the estimate: 10%; at least 6.6-fold (0.82 log units) between middle value and limit.
By their numbers in this assay, from the lowest: compounds 1 and 3 (each within the scatter of the next); then compound 2. At a limit, above all of these: compound 4.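

Exchanging (vinylcarbonyl)amino for methyl(2-(methylamino)ethyl)amino on the aromatic carbon next to the ring nitrogen gives an at least 5.1-fold higher number from compound 2 to compound 4 (0.71 log units; beyond the scatter) in this assay, the first measured sign that this position responds to the group it carries. The value of compound 4 is a limit, so the step has a lower bound and no exact size: the limit of > 10000 nM in this assay, at which 1 of the 4 values shown sits. On this read-out, the exchange moves towards weaker inhibition of growth, so this position is not indifferent to the change.

The compounds shown do not separate the loss of the (vinylcarbonyl)amino group from the arrival of the new chain, and this single pair is all that speaks to the position. As far as these compounds go, it also remains open how a plain amine or a longer chain ending in a morpholine would read here, and whether the same exchange would read alike on the core of compound 3.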